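Amide in Place of Urea: Expecting Another Limit

This account rests on a few compounds, and the source may have more. Where it says the series, first, only, none or still open, it means among the compounds named here.

Compound 1 `COc1cc(-c2nn(-c3cccc(NC(=O)Nc4ccc(Cl)c(Cl)c4)c3)cc2-c2ccncc2)ccc1Cl`: in a functional assay on DU-145 cells (Homo sapiens) for inhibition, read by sulforhodamine B assay, with a stated time of 48 h (on this read-out lower numbers stand for higher toxicity in this test and higher numbers for lower toxicity in this test), compound 1 gives > 50000 nM, which is a limit of the assay.
Compound 2 `O=C(Nc1cccc(-n2cc(-c3ccncc3)c(-c3ccc(Cl)c(O)c3)n2)c1)Nc1ccc(Cl)c(Cl)c1`: in this assay compound 2 gives > 32500 nM, again a limit.

Within the data shown here, compound 1 stands only at a limit, and the one further value shown is a limit too. The step that the two limits leave unreadable from compound 1 to compound 2 stays unreadable because the limit of > 32500 nM in this assay, at which 1 of the 2 values shown sits, and the limit of > 50000 nM in this assay, at which 1 of the 2 values shown sits, cap both numbers. Compound 3 `COc1cc(-c2nn(-c3cccc(NC(=O)c4ccc(Cl)c(C(F)(F)F)c4)c3)cc2-c2ccncc2)ccc1Cl` differs from compound 1 by 4-chloro-3-(trifluoromethyl)phenyl in place of (3,4-dichlorophenyl)amino on a carbonyl carbon, which turns the urea into an amide. Among the measured compounds shown here, no measured step bears on such a change, and the single measured step gives no size at all. The expected step of a number no higher from compound 1 to compound 3 (the limit leaves the size open) is therefore no readable change but a continuation at the same limit. For compound 3 the estimate in this assay is 50000 nM, within 15000 nM to 120000 nM, most likely reported again as a limit.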

Compound 3, concentration lethal to 50% of the cells: > 32500 nM
Compound 3: only a limit was reported; the forecaster's own chance of this, stated with the estimate: 70%; the middle value does not contradict the limit.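

Compound 1 and compound 3 both carry only limits in this assay, and the step between them cannot be read. The compounds shown leave open how toxic any of them is to these cells, and whether the amide in place of the urea changes that toxicity at all.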